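Chloro to fluoro on the aryl ring of compound 2

This account rests on a few compounds, and the source may have more. Where it says the series, first, only, none or still open, it means among the compounds named here.

The series is followed in a functional assay on MCF7 cells (Homo sapiens) for cytotoxicity, read by sulforhodamine B assay, with a stated time of 48 h; on this read-out higher numbers stand for weaker inhibition and lower numbers for stronger inhibition. Compound 1 `CC1=C(/C=C/C(=O)/C=C/c2ccc(Cl)cc2)C(C)(C)CCC1` gives 10200 nM and compound 2 `CC1=C(/C=C/C(=O)/C=C/c2ccccc2Cl)C(C)(C)CCC1` gives 54600 nM. Among the measured compounds shown here, the single measured step is a 5.4-fold higher number from compound 1 to compound 2 (0.73 log units; beyond the scatter), so compound 2 holds the highest of the two numbers so far, with compound 1 as its only neighbour.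

Compound 3 `CC1=C(/C=C/C(=O)/C=C/c2ccccc2F)C(C)(C)CCC1` differs from compound 2 by fluoro in place of chloro on an aromatic carbon; cut one bond further out this reads 2-chlorophenyl to 2-fluorophenyl. For the measured compounds named here, no measured step exchanges one halogen for another; the step from compound 1 to compound 2 puts 2-chlorophenyl in place of 4-chlorophenyl and does not bear directly on this swap. With nothing pointing in either direction, no step beyond the scatter is expected, and compound 3 is estimated at 45000 nM, range 15000 nM to 140000 nM, which means a 1.2-fold lower number from compound 2 to compound 3 (0.08 log units; within the scatter).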

Compound 3, half-maximal inhibitory concentration: 11000 nM
Compound 3: middle estimate off by 4.1-fold (0.61 log units), on the high side; the whole stated range lies above it.
By their numbers in this assay, from the lowest: compounds 1 and 3 (each within the scatter of the next); then compound 2.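

In this assay this aromatic carbon, ortho to a large group, does not treat the two halogens alike: fluoro in place of chloro gives a 5.0-fold lower number from compound 2 to compound 3 (0.70 log units; beyond the scatter), so one atom exchanged here is enough to move the number beyond the scatter. The 2-fluorophenyl and 4-chlorophenyl compounds show a 1.1-fold higher number from compound 1 to compound 3 (0.03 log units; within the scatter), which leaves compound 2 as the only one of the three set apart, and so the high number goes with 2-chlorophenyl specifically and not with any halogen at this position. Nothing on hand gives a measured reason for the gap between chloro and fluoro at this position.

As far as these compounds go, whether a bromo, a methoxy or an amino group on this carbon would fall with fluoro or with chloro remains open. From the compounds shown here alone, two halogens at one position also give no trend, and the effect of fluoro on the compound 1 pattern is unknown.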